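Trimethoxyphenyl series: replacing the indole at the bicyclic core

The source may hold more compounds than are shown below. What is called first, only, known or untested is meant among the compounds shown, and "the series" means these compounds.

Compound 1 `COc1cc(-c2ccnc3cc(-c4cn(C)c5ccccc45)nn23)cc(OC)c1OC` is the reference point of the pair measured so far. In a functional assay on HeLa cells (Homo sapiens) for inhibition, read by CCK-8 assay, with a stated time of 48 h (on this read-out higher numbers stand for weaker inhibition and lower numbers for stronger inhibition), compound 1 gives 399 nM, the lowest of the two numbers. Compound 2 `COc1cc(-c2ccnc3cc(-c4cn(C(=O)OC(C)(C)C)c5ccccc45)nn23)cc(OC)c1OC` gives 3770 nM in this assay; a 9.4-fold higher number from compound 1 to compound 2 (0.98 log units; beyond the scatter). Compound 3 `COc1cc(-c2ccnc3cc(-c4ccc(C(C)(C)C)cc4)nn23)cc(OC)c1OC` is not yet measured. The change from compound 1 is 4-(tert-butyl)phenyl in place of 1-methyl-1H-indol-3-yl on an aromatic carbon. Within the data shown here, no measured step concerns this exact exchange: the only step available alters the substituent on the aromatic nitrogen of the 1-methyl-1H-indol-3-yl group while keeping that group, and it moved the number by a 9.4-fold higher number from compound 1 to compound 2 (0.98 log units; beyond the scatter). It shows that the number is sensitive to changes at this group, but not how removal of the whole group behaves. A modest move towards a higher number is expected for compound 3, a 3.8-fold higher number from compound 1 to compound 3 (0.58 log units; beyond the scatter). For compound 3 in this assay the estimate is 1500 nM, with a range from 400 nM to 6000 nM.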

Compound 3, half-maximal inhibitory concentration: > 10000 nM
Compound 3 gave a limit, no number; the forecaster's own chance of this, stated with the estimate: 5%; middle value at least 6.6-fold (0.82 log units) from the limit.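

In this assay the reading for compound 3 is a limit of the assay and not a number: the limit of > 10000 nM in this assay, at which 1 of the 3 values shown sits.

Exchanging 1-methyl-1H-indol-3-yl for 4-(tert-butyl)phenyl on this aromatic carbon gives an at least 25-fold higher number from compound 1 to compound 3 (1.39 log units; beyond the scatter), a large step. Among these compounds, the earlier change, a 9.4-fold higher number from compound 1 to compound 2 (0.98 log units; beyond the scatter), kept the indole and altered only the substituent on its nitrogen, so the new step is the first to show that replacing the whole group also moves the number upward, here to the limit of the assay.

The compounds shown do not separate the departure of the five-membered aromatic ring and its nitrogen from the arrival of the tert-butyl group. From the compounds shown here alone, how a plain phenyl, a pyridine ring or an aryl group carrying an amine would read on this carbon remains open.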